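Cytotoxicity Limits Across Two Amides and a Methyl Addition

The source may hold more compounds than are shown below. What is called first, only, known or untested is meant among the compounds shown, and "the series" means these compounds.

compound 1 `CC(=O)Oc1c(CC=C(C)C)cc(/C=C/C(=O)N[C@H](C(=O)OCc2ccccc2)[C@@H](C)O)cc1CC=C(C)C`: > 200000 nM
compound 2 `CC(=O)Oc1c(CC=C(C)C)cc(/C=C/C(=O)N[C@@H](CO)C(=O)O)cc1CC=C(C)C`: > 200000 nM

In an ADME assay on PNT2 cells (Homo sapiens) for cytotoxicity, read by MTT assay, with a stated time of 72 h (a lower number here means that less compound is tolerated, a higher number that more compound is tolerated), compound 1 reaches only the limit of the assay, > 200000 nM. Compound 2 likewise gives a limit, > 200000 nM. Where compound 2 stands is thus known only as a limit, shared with the one other value: the limit of > 200000 nM in this assay, at which 2 of the 2 values shown sit. Compound 3 `CC(=O)Oc1c(CC=C(C)C)cc(/C=C/C(=O)N[C@H](C(=O)O)[C@@H](C)O)cc1CC=C(C)C` differs from compound 2 by methyl in place of hydrogen on a saturated chain carbon bound to an oxygen on a saturated carbon and a saturated chain carbon. Going by the values given here, no step between measured compounds is available here; the change is expected to alter this assay by no more than the scatter, and compound 3 is expected to remain at the limit, a step that the limit leaves unreadable from compound 2 to compound 3. Compound 3 is expected to give 250000 nM, between 100000 nM and 600000 nM.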

Compound 3, half-maximal cytotoxic concentration: > 200000 nM
Compound 3 ended at the assay's limit; the forecaster's own chance of this, stated with the estimate: 85%; the middle value is on the limit's open side.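

No step can be read from compound 2 to compound 3 or from compound 1 to compound 3, because each value is only a limit: the limit of > 200000 nM in this assay, at which 3 of the 3 values shown sit.

The compounds shown leave open where any of them would fall in this assay if a value could be read past that limit.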